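A few compounds are considered here, and "the series" means these few. Any claim that something is new, unique, unknown or untested is made for them only; others in the source may bear on it.

Three compounds with a shared core differ only in the group on a saturated ring carbon. In a functional assay on Ehrlich cells (Mus musculus) for antiproliferative activity, read by trypan blue exclusion, with a stated time of 2 h, tested at 50 ug/mL (a lower number here means a weaker effect, a higher number a stronger effect of the compound at the concentration tested), compound 1 `Cc1ccc(C2C(C#N)=C(N)N(c3ccc(S(N)(=O)=O)cc3)C3=C2C(=O)CCC3)cc1` gives 50%. Compound 2 `N#CC1=C(N)N(c2ccc(S(N)(=O)=O)cc2)C2=C(C(=O)CCC2)C1/C=C/c1ccccc1` gives 40% in this assay, a change of a number 10 percentage points lower from compound 1 to compound 2 (within the scatter). Compound 3 `N#CC1=C(N)N(c2ccc(S(N)(=O)=O)cc2)C2=C(C(=O)CCC2)C1c1ccc(Cl)cc1Cl` gives 65% and is the highest of the three numbers, with a number 15 percentage points higher from compound 1 to compound 3 (beyond the scatter) and a number 25 percentage points higher from compound 2 to compound 3 (beyond the scatter).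

Compound 4 `COc1ccc2ccccc2c1C1C(C#N)=C(N)N(c2ccc(S(N)(=O)=O)cc2)C2=C1C(=O)CCC2` differs from compound 3 at the same place: 2-methoxynaphthalen-1-yl in place of 2,4-dichlorophenyl on a saturated ring carbon. The two steps that bear on this are those leading into compound 3, which each swapped a ring-bearing group at this carbon for 2,4-dichlorophenyl and moved the read-out by modest amounts. For the measured compounds named here, no measured step introduces 2-methoxynaphthalen-1-yl, so its own effect is unknown; the three numbers span only a modest range, and a modest step downward or none beyond the scatter is expected in this assay. Compound 4 is therefore expected to give about 52%, with a range from 32% to 72%. That estimate means an expected step of a number 13 percentage points lower from compound 3 to compound 4 (beyond the scatter).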

Compound 4, a percentage reported as activity, at one concentration (the size of the read-out at that concentration, not a potency): 70%
Beside the measured number, compound 4's estimate is 18 percentage points below it; the measured number falls inside the stated range.
By their numbers in this assay, from the lowest: compounds 2 and 1 (each within the scatter of the next); then compounds 3 and 4 (each within the scatter of the next).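

In this assay, 2-methoxynaphthalen-1-yl, with 12 heavy atoms and 2 six-membered aromatic rings, can replace 2,4-dichlorophenyl, with 8 heavy atoms and one such ring, without a change beyond the scatter: a number 5 percentage points higher from compound 3 to compound 4 (within the scatter). The new group also clearly exceeds the two other groups at this saturated ring carbon, with a number 30 percentage points higher from compound 2 to compound 4 (beyond the scatter) and a number 20 percentage points higher from compound 1 to compound 4 (beyond the scatter), so two quite different groups now share the top of this small series. Nothing measured here explains why these two groups give such similar results.

Going by these compounds, it remains open whether a saturated group such as cyclohexyl, or a phenyl ring carrying an amine or a carboxylic acid, would keep this level of activity at the same carbon. On these data alone, because the read-out comes from a single concentration, it also remains open how compound 3 and compound 4 would compare across a range of concentrations.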